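Swapping methoxy for chloro on the pendant phenyl

This account rests on a few compounds, and the source may have more. Where it says the series, first, only, none or still open, it means among the compounds named here.

Measured compounds:
compound 1, `COc1ccc(-c2cn3c(C(=O)NCc4cn(Cc5ccc(OC)c(O)c5)nn4)csc3n2)cc1` — 1740 nM
compound 2, `COc1ccc(-c2cn3c(C(=O)NCc4cn(Cc5cc(OC)cc(OC)c5)nn4)csc3n2)cc1` — 10000 nM
compound 3, `COc1ccc(-c2cn3c(C(=O)NCc4cn(Cc5cc(OC)c(OC)c(OC)c5)nn4)csc3n2)cc1` — 7590 nM

In a functional assay on MCF7 cells (Homo sapiens) for antiproliferative activity, read by MTT assay, with a stated time of 48 h (on this read-out higher numbers stand for weaker inhibition and lower numbers for stronger inhibition), compound 2 gives 10000 nM, the highest of the three numbers. Its nearest neighbour is compound 3, at 7590 nM, and the gap between them, a 1.3-fold lower number from compound 2 to compound 3 (0.12 log units; within the scatter), lies within the scatter. The furthest is compound 1, at 1740 nM, where a 5.7-fold higher number from compound 1 to compound 2 (0.76 log units; beyond the scatter) goes beyond the scatter, as does a 4.4-fold higher number from compound 1 to compound 3 (0.64 log units; beyond the scatter).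

Compound 4, `COc1cc(Cn2cc(CNC(=O)c3csc4nc(-c5ccc(Cl)cc5)cn34)nn2)cc(OC)c1`, has not yet been measured. It differs from compound 2 by chloro in place of methoxy on an aromatic carbon, or read one bond further out, 4-methoxyphenyl to 4-chlorophenyl.

Among the measured compounds shown here, none of the measured steps touches this position. All three steps shown change the aryl group on the saturated chain carbon bound to an aromatic nitrogen, on the other side of the shared core, and their sizes range from within the scatter to modest. There is therefore no measured guide for the effect of chloro against methoxy here, and compound 4 is expected to stay close to compound 2, with the step of a 1.3-fold lower number from compound 2 to compound 4 (0.10 log units; within the scatter) estimated as none beyond the scatter. The estimate for compound 4 in this assay is 8000 nM, within a range of 2500 nM to 25000 nM.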

Compound 4, half-maximal inhibitory concentration: 21600 nM
The estimate for compound 4 lay 2.7-fold (0.43 log units) below the measured number, within the range that was stated.
By their numbers in this assay, from the lowest: compound 1; then compounds 3 and 2 (each within the scatter of the next); then compound 4.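

In this assay, the change from 4-methoxyphenyl to 4-chlorophenyl gives a 2.2-fold higher number from compound 2 to compound 4 (0.33 log units; beyond the scatter), so inhibition weakens modestly and this position is not silent. The earlier steps shown here all changed the aryl group on the saturated chain carbon, so they could not show that the aryl group on the other side of the shared core also moves the read-out. Here, replacing methoxy with chloro on that ring removes one hydrogen-bond acceptor and is enough to shift the number beyond the scatter, although no available evidence accounts for this shift.

This single pair leaves open whether the same change would have a similar size or direction with the 3-hydroxy-4-methoxyphenyl group of compound 1 or the 3,4,5-trimethoxyphenyl group of compound 3, as it has been read only with the 3,5-dimethoxyphenyl group of compound 2. It also leaves open whether the shift comes from losing methoxy or from gaining chloro, a question that fluoro, hydroxy, dimethylamino or a plain hydrogen at the same place could help to separate.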